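Swapping Methoxy for Bromo on a Glucuronidase Inhibitor

This account rests on a few compounds, and the source may have more. Where it says the series, first, only, none or still open, it means among the compounds named here.

Measured compounds:
compound 1 `Clc1ccc(Nc2nnc(-c3ccccc3)s2)cc1Cl` — 6280 nM
compound 2 `COc1ccc(-c2nnc(Nc3ccc(Cl)c(Cl)c3)s2)cc1` — 4160 nM
compound 3 `Cc1ccc(-c2nnc(Nc3cccc(Br)c3)s2)c(C)c1` — 36100 nM

In an assay on isolated protein for inhibition of beta-glucuronidase (Bos taurus), read by spectrophotometry, with a stated time of 30 min (on this read-out higher numbers stand for weaker inhibition and lower numbers for stronger inhibition), compound 2 gives the lowest number of the three. Compound 1 stands closest to it, within the usual scatter, so the two cannot be ranked; compound 3 lies clearly higher, beyond the scatter. Within the data shown here, the only step measured so far between neighbours is a 1.5-fold lower number from compound 1 to compound 2 (0.18 log units; within the scatter), a change too small to count as a real gain.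

Compound 4 `Clc1ccc(Nc2nnc(-c3ccc(Br)cc3)s2)cc1Cl` differs from compound 2 in one place: bromo in place of methoxy on an aromatic carbon. Among the measured compounds shown here, no measured pair shows a methoxy turning into a bromo, so the expectation rests on the small size of the methoxy step alone. Because that step, a 1.5-fold lower number from compound 1 to compound 2 (0.18 log units; within the scatter), stayed within the scatter, a swap of the group at this place is expected to move this assay little, in no sure direction. Compound 4 is therefore estimated at 5000 nM, with a range from 2000 nM to 15000 nM. The expected step of a 1.2-fold higher number from compound 2 to compound 4 (0.08 log units; within the scatter) is within the scatter.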

Compound 4, half-maximal inhibitory concentration: 7160 nM
The estimate for compound 4 lay 1.4-fold (0.16 log units) below the measured number; the measured number falls inside the stated range.
By their numbers in this assay, from the lowest: compounds 2, 1 and 4 (each within the scatter of the next); then compound 3.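

In this assay, the aromatic carbon para to a large group has now carried hydrogen, methoxy and bromo on the same core, and the two new steps are both small (a 1.7-fold higher number from compound 2 to compound 4 (0.24 log units; within the scatter)) and (a 1.1-fold higher number from compound 1 to compound 4 (0.06 log units; within the scatter)). Methoxy brings a hydrogen-bond acceptor and bromo brings none, yet the swap stays within the usual scatter, and neither group can be told apart from plain hydrogen at this place. Nothing measured here offers an explanation for this flat result.

Going by these compounds, what an amine, a carboxylic acid or a longer chain would do at this place stays open. Compound 3 differs from these compounds in more than one place, so its higher number cannot be assigned to any single group.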